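The source may report more compounds than this note shows. Statements on the series, on what has been measured and on what is new or still open speak of the compounds shown alone.

Compound 1, `CC(C)(C)c1ccc(Cc2cccn(-c3ccc4c(c3)OCCO4)c2=O)cc1`: > 4000 nM
Compound 2, `CC(C)(C)c1ccc(-c2cc(Nc3ccc4c(c3)OCCO4)ncn2)cc1`: 680 nM

Among the compounds with values here, of the two compounds measured in a functional assay on CHO cells for antagonist activity at transient receptor potential cation channel subfamily V member 1 (Rattus norvegicus), read by calcium flux (a higher number here means a weaker inhibitor, a lower number a stronger inhibitor), compound 2 is the only one with a number, its value being 680 nM. Compound 1 sits at the limit of > 4000 nM in this assay, at which 1 of the 2 values shown sits, which is a limit of the assay rather than a number. Within the data shown here, no step between measured compounds is recorded, so nothing here tells what size of change a replacement of the tert-butyl group would bring. Compound 3, `FC(F)(F)c1ccc(-c2cc(Nc3ccc4c(c3)OCCO4)ncn2)cc1`, is the untested compound; it differs from compound 2 by trifluoromethyl in place of tert-butyl on an aromatic carbon. Among the measured compounds shown here, with no comparable step measured, the expected step is a 1.5-fold higher number from compound 2 to compound 3 (0.17 log units; within the scatter), judged small and lying within or near the scatter, with weakening somewhat more likely than strengthening. Compound 3 is therefore estimated at 1000 nM in this assay, with a range of 300 nM to 3500 nM.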

Compound 3, half-maximal inhibitory concentration: 1200 nM
For compound 3 the middle estimate is 1.2-fold (0.08 log units) below the measured one, within the range that was stated.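

Within the data shown here, this is the first measured step at this position: in this assay, trifluoromethyl in place of tert-butyl on an aromatic carbon, para to a large group, gives a 1.8-fold higher number from compound 2 to compound 3 (0.25 log units; within the scatter). On this reading, the two groups cannot be told apart at this place on the shared core, although they differ in their atoms and match in their count of heavy atoms. Nothing available bears on why the exchange reads this way.

The compounds shown leave open what a nitrile, an amine or a carboxylic acid would give at this same place, since both groups compared here carry no hydrogen-bond donors or acceptors and no net charge. They also leave open whether this exchange would read the same on a different core.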